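The compounds below may be only part of what the source reports. "The series", "measured", "known", "first", "only" and "open" are said of these compounds alone.

Compound 3 `CCOC(=O)CCCCCOc1cccc(CN(C(=O)c2ccc(-c3cccc(OC(F)(F)F)c3)cc2)C(C)C)c1` is the anchor of this note. In an ADME assay on HepG2 cells (Homo sapiens) for cytotoxicity, read by CellTiter-Glo and resazurin assay, with a stated time of 72 h (on this read-out lower numbers stand for an effect already at smaller amounts and higher numbers for an effect only at larger amounts of compound), compound 3 reaches only a limit of the assay, > 26000 nM. Compound 1 `CCOC(=O)CCCCCOc1cccc(CN(C(=O)c2ccc(-c3ccco3)cc2)C(C)C)c1` likewise stops at a limit in this assay, > 26000 nM. Compound 2 `CCOC(=O)CCCCCOc1cccc(CN(C(=O)c2ccc(-c3cccc(OCc4ccccc4)c3)cc2)C(C)C)c1` also returns a limit in this assay, > 26000 nM. All three values sit at the same ceiling, (the limit of > 26000 nM in this assay, at which 3 of the 3 values shown sit), so no ordering among compounds 1, 2 and 3 can be read from them. The step that the two limits leave unreadable from compound 1 to compound 3 accordingly has no readable size, and the same holds for a step that the two limits leave unreadable from compound 2 to compound 3.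

Compound 4 `CCOC(=O)CCCCCOc1cccc(CN(C(=O)c2ccc(-c3cccc(F)c3)cc2)C(C)C)c1` is the member still to be measured in this assay. It differs from compound 3 in one place: fluoro in place of trifluoromethoxy on an aromatic carbon. Both measured steps that end at compound 3 are unreadable, so they supply no size to carry over; what they do show is that three different groups at this part of the shared core all left the value at the limit. On that basis the step that the limit leaves unreadable from compound 3 to compound 4 is expected to be none beyond the scatter, with compound 4 most likely also reported as a limit. Compound 4 is expected at 40000 nM, within a range from 20000 nM to 120000 nM.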

Compound 4, half-maximal effective concentration: > 26000 nM
Compound 4 was reported as a limit; the forecaster's own chance of this, stated with the estimate: 85%; the middle value lies beyond the limit too.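

No new step can be read in this assay: compound 4 stops at the same limit as compounds 1, 2 and 3, so its steps from each of them have no readable size, and all four compounds sit at one ceiling: the limit of > 26000 nM in this assay, at which 4 of the 4 values shown sit.

The compounds shown leave open whether these four differ at all on this read-out, and no measured value gives any of them a position.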